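Working notes: methyl-to-hydrogen steps in a small series

A few compounds are considered here, and "the series" means these few. Any claim that something is new, unique, unknown or untested is made for them only; others in the source may bear on it.

All values come from an assay on FRT-Jurkat cells for inhibition of nuclear factor NF-kappa-B complex (Homo sapiens), read by flow cytometry, with a stated time of 24 h, tested at 10 uM; a lower number here means less inhibition, a higher number more inhibition at the concentration tested (going by the name of the read-out).

compound 1 `Cc1ccc(Nc2ccc3c(c2)C(=O)N(C2CCC(=O)NC2=O)C3=O)cc1`: 5%
compound 2 `CC(C)(C)c1ccc(Nc2cccc3c2C(=O)N(C2CCC(=O)NC2=O)C3=O)cc1`: 36%
compound 3 `CCc1ccc(Nc2ccc3c(c2)C(=O)N(C2CCC(=O)NC2=O)C3=O)cc1`: 5%

Compound 2 stands highest of the three; compound 1 and compound 3 both lie well below it, beyond the scatter. The difference between the core of compound 2 and the core of compound 3 is not broken down here.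

One structural change is seen twice. From compound 3 to compound 1 it reads (hydrogen in place of methyl on a saturated chain carbon bound to an aromatic carbon), and the step is no change at the digits printed from compound 3 to compound 1 (within the scatter). The not yet measured compound 4 `CC(C)c1ccc(Nc2cccc3c2C(=O)N(C2CCC(=O)NC2=O)C3=O)cc1` arises from compound 2 by hydrogen in place of methyl on a saturated chain carbon bound to an aromatic carbon and two saturated chain carbons; this is the same kind of change, but the place differs: here the saturated chain carbon is bound to an aromatic carbon and two saturated chain carbons, whereas in the earlier pair it is bound to an aromatic carbon only.

On that single precedent, compound 4 is expected to sit close to compound 2, with a step of a number 8 percentage points lower from compound 2 to compound 4 (within the scatter), because the earlier step of no change at the digits printed from compound 3 to compound 1 (within the scatter) stayed within the scatter. A modest loss is allowed for in the range, since the surroundings of the place differ. Compound 4 is estimated at 28%, between 10% and 45%.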

Compound 4, a percentage reported as inhibition, at one concentration (the size of the read-out at that concentration, not a potency): 19%
The estimate for compound 4 lay 9 percentage points above the measured number, within the range that was stated.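

In this assay, hydrogen in place of methyl does not carry from one core to the other at a fixed size: the same change on two cores in this assay, no change at the digits printed (within the scatter) from compound 3 to compound 1 and a number 17 percentage points lower (beyond the scatter) from compound 2 to compound 4, 17 percentage points apart, beyond the scatter of two such steps

On the core of compound 2, going from tert-butyl to isopropyl gives a number 17 percentage points lower from compound 2 to compound 4 (beyond the scatter), so any reading of this change in the series has to be tied to the core and the place where it occurs. What this does not show is which of the two matters: the pairs differ in the core and also in the place of the change, a saturated chain carbon bound to an aromatic carbon only against one bound to an aromatic carbon and two saturated chain carbons, and one pair on each side cannot separate these.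

Left open is whether the step would hold with the tert-butyl to isopropyl change on the core of compound 3. Also open, as far as these compounds go, is how the read-out responds when the saturated chain on the phenyl ring gives way to an amine or a carboxylic acid.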